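A few compounds are considered here, and "the series" means these few. Any claim that something is new, unique, unknown or untested is made for them only; others in the source may bear on it.

Series notes, compound 4 pending.

Compound 2 `CC(=O)N[C@@H]1CCCc2c1cncc2N1Cc2cc(Cl)ccc2C1=O` carries the shared core with an acetamido group and gives 2330 nM in an ADME assay on cells for inhibition of cytochrome P450 11B1, mitochondrial (Homo sapiens), read by HTRF; on this read-out lower numbers stand for stronger inhibition and higher numbers for weaker inhibition. Compound 1 `CC[C@@H]1c2cc(Cl)ccc2C(=O)N1c1cncc2c1CCC[C@H]2NC(C)=O` adds to that core the change (ethyl in place of hydrogen on a saturated ring carbon), and in this assay compound 1 gives 334 nM; the step is a 7.0-fold lower number from compound 2 to compound 1 (0.84 log units; beyond the scatter). Compound 3 `CCC(=O)N[C@@H]1CCCc2c1cncc2N1Cc2cc(Cl)ccc2C1=O` differs from compound 2 by methyl in place of hydrogen on a saturated chain carbon bound to a carbonyl carbon, and in this assay compound 3 gives 5210 nM, a step of a 2.2-fold higher number from compound 2 to compound 3 (0.35 log units; beyond the scatter). Among the three measured compounds, compound 3 stands at the highest number, with compound 2 nearest and compound 1 furthest.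

Compound 4 `CCC(=O)N[C@@H]1CCCc2c1cncc2N1C(=O)c2ccc(Cl)cc2[C@H]1CC` is built from compound 3 by ethyl in place of hydrogen on a saturated ring carbon. Going by the values given here, this is the same change as the one from compound 2 to compound 1, made here on the propanoylamino core of compound 3 instead of the acetamido core of compound 2; the two cores differ by methyl in place of hydrogen on a saturated chain carbon bound to a carbonyl carbon. The change occurs twice among the compounds considered, once measured and once pending.

Among the compounds with values here, for compound 4 in this assay, the expectation rests on the single measured instance, a 7.0-fold lower number from compound 2 to compound 1 (0.84 log units; beyond the scatter), applied to the starting number of compound 3, 5210 nM. On that basis the expected step is a 6.5-fold lower number from compound 3 to compound 4 (0.81 log units; beyond the scatter), taken as roughly the size of the earlier one, with a wider band because it is carried by one pair only and the cores are not identical. The estimated value for compound 4 in this assay is 800 nM, expected to fall between 350 nM and 2000 nM.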

Compound 4, half-maximal inhibitory concentration: 10200 nM
For compound 4 the middle estimate is 13-fold (1.11 log units) below the measured one; measured number above the stated range.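

In this assay, ethyl in place of hydrogen on a saturated ring carbon does not carry its effect from the acetamido core to the propanoylamino core, where the step is a 2.0-fold higher number from compound 3 to compound 4 (0.29 log units; within the scatter), and the two instances differ: the same change on two cores in this assay, a 7.0-fold lower number (0.84 log units; beyond the scatter) from compound 2 to compound 1 and a 2.0-fold higher number (0.29 log units; within the scatter) from compound 3 to compound 4, 14-fold (1.14 log units) apart, beyond the scatter of two such steps. The methyl change on the acyl chain also depends on its partner, since with the ethyl group present the step is a 31-fold higher number from compound 1 to compound 4 (1.48 log units; beyond the scatter), and this too differs from its earlier instance: the same change on two cores in this assay, a 2.2-fold higher number (0.35 log units; beyond the scatter) from compound 2 to compound 3 and a 31-fold higher number (1.48 log units; beyond the scatter) from compound 1 to compound 4, 14-fold (1.14 log units) apart, beyond the scatter of two such steps. These four compounds therefore show that the two changes do not add up independently here, so a step read on one core gives no safe estimate for the other, but they do not show what lies behind this, and a single set of four compounds sets no rule for the wider series.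

Going by these compounds, it remains open whether the lower number with ethyl is confined to the acetamido group or would also appear with a butanoylamino group or a free amine in its place. On these data alone, it is also open how a methyl or a propyl group in place of the ethyl would behave on either core.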